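The compounds below may be only part of what the source reports. "The series", "measured", "known", "first", "only" and "open" are said of these compounds alone.

Measured in a functional assay (aorta) with Oryctolagus cuniculus as the target; a lower number here means tighter binding, a higher number weaker binding:
compound 1 `COc1cc(C(C)=O)ccc1OCCCN1CCC(C(c2ccc(F)cc2)c2ccc(F)cc2)CC1` gives 1.59 nM
compound 2 `COc1cc(C(C)=O)ccc1OCCCN1CCC(Cc2ccc(F)cc2)CC1` gives 20 nM
compound 3 `COc1cc(C(C)=O)ccc1OCCCN1CCC(C(C(N)=O)(c2ccc(F)cc2)c2ccc(F)cc2)CC1` gives 25.1 nM

Compound 1 stands lowest of the three numbers in this assay. Both measured steps move away from it and both are large: hydrogen in place of 4-fluorophenyl gives a 13-fold higher number from compound 1 to compound 2 (1.10 log units; beyond the scatter), and carbamoyl in place of hydrogen on the saturated chain carbon bound to two aromatic carbons and a saturated ring carbon gives a 16-fold higher number from compound 1 to compound 3 (1.20 log units; beyond the scatter). Compound 1 is thus sensitive to alteration at that carbon.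

Compound 4 `Fc1ccc(C(c2ccc(F)cc2)C2CCN(CCCSc3ccccc3)CC2)cc1` is not yet measured. Its change from compound 1 is phenylsulfanyl in place of 4-acetyl-2-methoxyphenoxy on a saturated chain carbon, three bonds along the chain from an amine nitrogen in a ring. Neither measured step touches the saturated chain carbon three bonds along the chain from an amine nitrogen in a ring; both concern the saturated chain carbon bound to two aromatic carbons and a saturated ring carbon, and the part of compound 1 that is exchanged here is left untouched in compounds 2 and 3. The measured steps therefore give no direct bearing on this change. The expectation is a step toward a higher number of moderate size, smaller than the two measured steps, with wide uncertainty: a 3.1-fold higher number from compound 1 to compound 4 (0.50 log units; beyond the scatter) is the estimated step. Compound 4 is expected at 5 nM in this assay. The estimated range for compound 4 runs from 1 nM to 30 nM.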

Compound 4, dissociation constant: 3.16 nM
Beside the measured number, compound 4's estimate is 1.6-fold (0.20 log units) above it; low and high end bracket the measured number.
By their numbers in this assay, from the lowest: compounds 1 and 4 (each within the scatter of the next); then compounds 2 and 3 (each within the scatter of the next).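

In this assay the exchange at the saturated chain carbon, three bonds along the chain from an amine nitrogen in a ring, gives a 2.0-fold higher number from compound 1 to compound 4 (0.30 log units; within the scatter) and so stays inside the usual scatter, whereas both earlier steps, made at the saturated chain carbon bound to two aromatic carbons and a saturated ring carbon, lay beyond it. Going by these compounds alone, this is the first reading at this position, and it shows that the number holds when phenylsulfanyl with 7 heavy atoms and 1 hydrogen-bond acceptor replaces 4-acetyl-2-methoxyphenoxy with 12 heavy atoms and 3 hydrogen-bond acceptors. Nothing available here accounts for this outcome.

Within the data shown here, the single exchange alters the sulfur or oxygen link and the ring substituents together, so the share of the acetyl, the methoxy and the linking atom remains unresolved. Also open, from the compounds shown here alone, are how a carboxylic acid or an amine on the aromatic ring would read in this assay, and whether a longer chain at this position would leave the number within the scatter.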